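The source may hold more compounds than are shown below. What is called first, only, known or untested is meant among the compounds shown, and "the series" means these compounds.

Working notes on the series. Three members of the series have been measured in a functional assay on A549 cells (Homo sapiens) for inhibition, read by CCK-8 assay, with a stated time of 72 h, tested at 1 uM; a higher number here means more inhibition of growth at the concentration tested, a lower number less inhibition of growth. Compound 1 `Cc1cccc(NC(=O)C2(C(=O)Nc3ccc(Nc4ncc5cc(C(=O)N(C)C)n(C6CCCC6)c5n4)cc3)CC2)c1` gives 35.2% in this assay. Compound 2 `COC(=O)c1ccc(NC(=O)C2(C(=O)Nc3ccc(Nc4ncc5cc(C(=O)N(C)C)n(C6CCCC6)c5n4)cc3)CC2)cc1` gives 77.1%, and compound 3 `CN(C)C(=O)c1cc2cnc(Nc3ccc(NC(=O)C4(C(=O)Nc5cccc(F)c5)CC4)cc3)nc2n1C1CCCC1` gives 33.2%. Among the three, compound 1 stands second highest; its nearest neighbour is compound 3, whose value lies within the scatter of it, and its furthest is compound 2, which lies beyond the scatter above it.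

Compound 4 `CN(C)C(=O)c1cc2cnc(Nc3ccc(NC(=O)C4(C(=O)Nc5ccccc5)CC4)cc3)nc2n1C1CCCC1` is not yet measured in this assay. It differs from compound 1 in one place: hydrogen in place of methyl on an aromatic carbon.

Of the measured steps, the one most like it is a number 2 percentage points lower from compound 1 to compound 3 (within the scatter), which also exchanges the group on that aromatic carbon, meta to a large group, and stays within the scatter. The large steps, a number 41.9 percentage points higher from compound 1 to compound 2 (beyond the scatter) and a number 43.9 percentage points lower from compound 2 to compound 3 (beyond the scatter), both involve the 4-(methoxycarbonyl)phenyl group on the amide-type nitrogen, a change not made here. For compound 4 no step beyond the scatter is therefore expected in this assay, in either direction.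

The expected value for compound 4 is 33%, with a range of 20% to 48%, which means an expected step of a number 2.2 percentage points lower from compound 1 to compound 4 (within the scatter).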

Compound 4, percent growth inhibition at one concentration: 75%
Compound 4: the middle estimate sits 42 percentage points below what was measured; the whole stated range lies below it.
By their numbers in this assay, from the lowest: compounds 3 and 1 (each within the scatter of the next); then compounds 4 and 2 (each within the scatter of the next).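

The unsubstituted phenyl changes the reading of this position on the ring, meta to a large group: hydrogen in place of methyl gives a number 39.8 percentage points higher from compound 1 to compound 4 (beyond the scatter), and hydrogen in place of fluoro gives a number 41.8 percentage points higher from compound 3 to compound 4 (beyond the scatter), whereas the exchange of methyl for fluoro alone, a number 2 percentage points lower from compound 1 to compound 3 (within the scatter), had suggested a position that tolerates change. In this assay, the step of a number 2.1 percentage points lower from compound 2 to compound 4 (within the scatter) shows that the high level does not depend on the methoxycarbonyl group, and the low numbers of the 3-methylphenyl and 3-fluorophenyl compounds are not shared by every substituted ring, as the 4-(methoxycarbonyl)phenyl of compound 2 goes against any such rule. No measurement at hand bears on why methyl and fluoro at this place sit so far from hydrogen.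

The compounds shown leave open whether any group at this place stays low, or only methyl and fluoro do, as a 3-aminophenyl or a 3-(methoxycarbonyl)phenyl would tell. They also leave open whether the place on the ring decides the outcome, which a 4-methylphenyl or a 4-fluorophenyl would test against compound 1 and compound 3.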